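Replacing the 2-chloro-4-fluorophenyl group of compound 3

The compounds below may be only part of what the source reports. "The series", "measured", "known", "first", "only" and "open" are said of these compounds alone.

In a functional assay on HepG2 cells (Homo sapiens) for antiproliferative activity, read by MTT assay, with a stated time of 72 h (a lower number here means a stronger inhibitor, a higher number a weaker inhibitor), compound 1 (`O=C(N/N=C/c1ccccc1)Nc1ccc(Oc2ccnc3[nH]ccc23)c(F)c1`) gives 640 nM, compound 2 (`O=C(N/N=C/c1ccc([N+](=O)[O-])cc1)Nc1ccc(Oc2ccnc3[nH]ccc23)c(F)c1`) gives 3030 nM and compound 3 (`O=C(N/N=C/c1ccc(F)cc1Cl)Nc1ccc(Oc2ccnc3[nH]ccc23)c(F)c1`) gives 1110 nM. Compound 3 therefore stands level with compound 1 within the scatter, and clearly under compound 2.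

Compound 4 (`CN(C)CCn1cccc1/C=N/NC(=O)Nc1ccc(Oc2ccnc3[nH]ccc23)c(F)c1`) differs from compound 3 in one place, on a carbon with a double bond to nitrogen, where 1-(2-(dimethylamino)ethyl)-1H-pyrrol-2-yl stands in place of 2-chloro-4-fluorophenyl: 1-(2-(dimethylamino)ethyl)-1H-pyrrol-2-yl in place of 2-chloro-4-fluorophenyl on a carbon with a double bond to nitrogen.

Among the compounds with values here, three measured steps concern this same aromatic group: a 4.7-fold higher number from compound 1 to compound 2 (0.68 log units; beyond the scatter), a 1.7-fold higher number from compound 1 to compound 3 (0.24 log units; within the scatter) and a 2.7-fold lower number from compound 2 to compound 3 (0.44 log units; beyond the scatter). Within the data shown here, all three are small or modest, yet no measured compound carries a five-membered ring or this chain, so they offer only a rough guide. No step beyond the scatter is therefore expected, and the direction stays uncertain. In this assay the estimated step is a 1.4-fold lower number from compound 3 to compound 4 (0.14 log units; within the scatter). For compound 4 the estimated value is 800 nM, with an expected range from 200 nM to 3000 nM.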

Compound 4, half-maximal inhibitory concentration: 8980 nM
Estimate against measurement, compound 4: 11-fold (1.05 log units) below; the whole stated range lies below it.
By their numbers in this assay, from the lowest: compounds 1 and 3 (each within the scatter of the next); then compound 2; then compound 4.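

Within the data shown here, at this position, on a carbon with a double bond to nitrogen, the earlier changes among substituted and unsubstituted phenyl groups gave modest steps at most, but moving to a five-membered ring with a chain costs far more: in this assay the change gives an 8.1-fold higher number from compound 3 to compound 4 (0.91 log units; beyond the scatter) and also a 14-fold higher number from compound 1 to compound 4 (1.15 log units; beyond the scatter) which is the only large step in the set. Even the weakest earlier compound is passed, with a 3.0-fold higher number from compound 2 to compound 4 (0.47 log units; beyond the scatter) so the position clearly does not accept every aromatic group equally. No measurement of any property of these groups is available to explain this loss.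

The change swaps the ring and adds the chain at once, so the compounds shown cannot tell which of the two matters. A 1H-pyrrol-2-yl group without the chain, or a phenyl ring carrying the same 2-(dimethylamino)ethyl chain, would separate them.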